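Swapping a Methyl for a Fluorophenyl on the Fused Ring

This account rests on a few compounds, and the source may have more. Where it says the series, first, only, none or still open, it means among the compounds named here.

Compounds measured so far:
compound 1, `O=S(=O)(Nc1ccc(F)c(C#Cc2cnc3[nH]ccc3c2)c1F)c1cccnc1`: 1170 nM
compound 2, `O=S(=O)(Nc1ccc(F)c(C#Cc2ccc3[nH]ncc3c2)c1F)c1cccnc1`: a limit of the assay, > 10000 nM
compound 3, `Cc1n[nH]c2ncc(C#Cc3c(F)ccc(NS(=O)(=O)c4cccnc4)c3F)cc12`: 148 nM

In a functional assay on COLO 205 cells (Homo sapiens) for antiproliferative activity, read by MTT assay, with a stated time of 68 h (a lower number here means a stronger inhibitor, a higher number a weaker inhibitor), compound 3 gives the lowest number of the two numbers that are not limits, and the step of a 7.9-fold lower number from compound 1 to compound 3 (0.90 log units; beyond the scatter) lies beyond the scatter. Compound 2 sits at the limit of > 10000 nM in this assay, at which 1 of the 3 values shown sits, so its step of an at least 67-fold lower number from compound 2 to compound 3 (1.82 log units; beyond the scatter) is only a lower bound. Compound 4, `O=S(=O)(Nc1ccc(F)c(C#Cc2cnc3[nH]nc(-c4ccc(F)cc4)c3c2)c1F)c1cccnc1`, keeps the whole core of compound 3 and differs only in 4-fluorophenyl in place of methyl on an aromatic carbon. Among the compounds with values here, none of the measured steps bears on this kind of change: each of them, an at least 8.5-fold higher number from compound 1 to compound 2 (0.93 log units; beyond the scatter) and a 7.9-fold lower number from compound 1 to compound 3 (0.90 log units; beyond the scatter), swaps the entire fused ring system attached to the triple-bonded carbon, whereas here the fused ring stays and only one small substituent grows into a ring. For compound 4 the expected step of a 1.3-fold lower number from compound 3 to compound 4 (0.13 log units; within the scatter) is therefore small and uncertain in direction. The estimate for compound 4 in this assay is 110 nM, within a range from 20 nM to 800 nM.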

Compound 4, half-maximal inhibitory concentration: 166 nM
The estimate for compound 4 lay 1.5-fold (0.18 log units) below the measured number, and the stated range covers the measured number.
By their numbers in this assay, from the lowest: compounds 3 and 4 (each within the scatter of the next); then compound 1. At a limit, above all of these: compound 2.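

In this assay, 4-fluorophenyl in place of methyl gives a 1.1-fold higher number from compound 3 to compound 4 (0.05 log units; within the scatter) and so leaves the antiproliferative reading effectively unchanged. The earlier steps shown here each exchanged the whole fused ring system, whereas this one keeps the core of compound 3 and shows that, on this aromatic carbon of the five-membered ring, a methyl and a much larger aromatic ring give numbers that cannot be told apart. No measurement shown here accounts for this match between compound 3 and compound 4.

The compounds shown have only these two groups at this position, so the effect of an amine, a carboxylic acid or a longer alkyl chain there remains open. Also open, going by these compounds, is whether a phenyl ring without its fluorine would give a similar number.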